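The source may report more compounds than this note shows. Statements on the series, on what has been measured and on what is new or still open speak of the compounds shown alone.

Compound 2 `Cc1c(CN2CCCC2)cc(-c2ccc(F)cc2)n1Nc1ccnc2cc(Cl)ccc12` gives 3.45 in a physicochemical assay for lipophilicity, at pH 5.2; on this read-out higher numbers stand for higher lipophilicity and lower numbers for lower lipophilicity. Compound 1 `Cc1c(CN2CCCC2)cc(-c2ccccc2)n1Nc1ccnc2cc(Cl)ccc12` gives 3.28, and the difference, a number 0.17 log units higher from compound 1 to compound 2 (within the scatter), lies within the scatter, so the two cannot be ranked. Compound 3 `Cc1c(CN2CCCC2)cc(-c2ccc(C(F)(F)F)cc2)n1Nc1ccnc2cc(Cl)ccc12` gives 4.72, well apart: the step of a number 1.27 log units higher from compound 2 to compound 3 (beyond the scatter) is large and beyond the scatter. Compound 4 `Cc1c(CN2CCCC2)cc(-c2ccc(N)cc2)n1Nc1ccnc2cc(Cl)ccc12` differs from compound 2 by amino in place of fluoro on an aromatic carbon. Neither measured step tests this change directly: both a number 0.17 log units higher from compound 1 to compound 2 (within the scatter) and a number 1.27 log units higher from compound 2 to compound 3 (beyond the scatter) exchange fluorine-bearing groups, none an amino. The amino group adds one hydrogen-bond donor and one acceptor where fluoro had none, so a fall in this assay beyond the scatter is expected. For compound 4 the estimate is 2.3, between 1.7 and 2.9, a step of a number 1.15 log units lower from compound 2 to compound 4 (beyond the scatter).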

Compound 4, distribution coefficient: 2.03
Estimate against measurement, compound 4: 0.27 log units above; measured number inside the range.
By their numbers in this assay, from the lowest: compound 4; then compounds 1 and 2 (each within the scatter of the next); then compound 3.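

Until now, changes at this position had left the number in this assay level or raised it, and amino is the first group shown to lower it (a number 1.25 log units lower from compound 1 to compound 4 (beyond the scatter)). Replacing fluoro with amino also lowers it (a number 1.42 log units lower from compound 2 to compound 4 (beyond the scatter)). Replacing trifluoromethyl with amino gives the widest step (a number 2.69 log units lower from compound 3 to compound 4 (beyond the scatter)), so one group at this position can move the read-out a long way in either direction.

No measurement shown explains the fall. On these data alone, whether a hydroxyl or a methoxy group here would also lower the number, or a dimethylamino group would match amino, remains open.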